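The source may report more compounds than this note shows. Statements on the series, on what has been measured and on what is new or still open speak of the compounds shown alone.

Three compounds of the series have numbers in a functional assay, with a stated time of 150 min; a lower number here means a stronger inhibitor, a higher number a weaker inhibitor. Compound 1 `CCOC(=O)c1cnn(-c2nc(-c3ccccc3F)c(C#N)c(=O)n2C)c1N` gives 87 ug/mL in this assay. Compound 2 `CCOC(=O)c1cnn(-c2nc(-c3ccccc3Cl)c(C#N)c(=O)n2C)c1N` gives 93 ug/mL. Compound 3 `Cn1c(NN)nc(-c2ccccc2Cl)c(C#N)c1=O` has a core that differs from that of compound 2 in a way not broken down here. In this assay compound 3 gives 62 ug/mL; its nearest neighbour by number is compound 1 and its furthest is compound 2, both within the scatter, so no order among the three is claimed. For the measured compounds named here, the one change with a measured step is fluoro in place of chloro on an aromatic carbon, which gave a 1.1-fold lower number from compound 2 to compound 1 (0.03 log units; within the scatter). Compound 4 `Cn1c(NN)nc(-c2ccccc2F)c(C#N)c1=O`, not yet measured, carries the same change on the core of compound 3: fluoro in place of chloro on an aromatic carbon. The expected step is a 1.1-fold lower number from compound 3 to compound 4 (0.03 log units; within the scatter) because a 1.1-fold lower number from compound 2 to compound 1 (0.03 log units; within the scatter) stayed within the scatter. Compound 4 is expected to give 58 ug/mL, estimated between 30 ug/mL and 110 ug/mL.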

Compound 4, half-maximal inhibitory concentration: 60 ug/mL
For compound 4 the middle estimate is 1.0-fold (0.01 log units) below the measured one; measured number inside the range.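

In this assay, fluoro in place of chloro on an aromatic carbon gives a 1.0-fold lower number from compound 3 to compound 4 (0.01 log units; within the scatter). The change carries from one core to the other with no difference that can be told apart: the same change on two cores in this assay, a 1.1-fold lower number (0.03 log units; within the scatter) from compound 2 to compound 1 and a 1.0-fold lower number (0.01 log units; within the scatter) from compound 3 to compound 4, 1.0-fold (0.01 log units) apart, within the scatter of two such steps. This shows that the swap leaves the number within the scatter on both cores shown, but it does not show that the change has any real effect, or that the same would hold on other cores of the series.

The compounds shown leave open whether an amine, a methoxy group or a carboxylic acid on that aromatic carbon would move the number beyond the scatter. Also open, going by these compounds, is whether this step stays as small on a third core.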